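The source may hold more compounds than are shown below. What is called first, only, known or untested is meant among the compounds shown, and "the series" means these compounds.

Of the compounds shown here, three built on one shared core have been tested in a functional assay on SMMC-7721 cells (Homo sapiens) for inhibition, read by MTT assay, with a stated time of 72 h, tested at 25 uM; on this read-out lower numbers stand for less inhibition and higher numbers for more inhibition at the one concentration tested (going by the name of the read-out). Compound 1 `Cc1ccc(Oc2c(/C=N\OCc3c(Cl)c(-c4ccc(F)cc4)nn3C)c(C)nn2C)cc1` gives 80%. Compound 2 `COc1ccc(Oc2c(/C=N\OCc3c(Cl)c(-c4ccc(F)cc4)nn3C)c(C)nn2C)cc1` differs from it by methoxy in place of methyl on an aromatic carbon, and in this assay compound 2 gives 80%; the step of no change at the digits printed from compound 1 to compound 2 (within the scatter) shows that this exchange left the read-out where it was. Compound 3 `Cc1ccc(Oc2c(/C=N\OCc3c(Cl)c(-c4ccc(Cl)cc4)nn3C)c(C)nn2C)cc1` carries a different core, the difference being (chloro in place of fluoro on an aromatic carbon), and compound 3 gives 80%; the step of no change at the digits printed from compound 1 to compound 3 (within the scatter) is likewise within the scatter. Compound 4 `COc1ccc(Oc2c(/C=N\OCc3c(Cl)c(-c4ccc(Cl)cc4)nn3C)c(C)nn2C)cc1` has not yet been measured. It differs from compound 3 by methoxy in place of methyl on an aromatic carbon, which is the same change that was made from compound 1 to compound 2, at the same place on the ring. Only these two compounds show the change, so the expectation rests on that single earlier step. The expected step for compound 4 is no change at the digits printed from compound 3 to compound 4 (within the scatter), set beside the measured step from compound 1 to compound 2. Compound 4 is therefore estimated to give 80%, with a range from 68% to 90% expected.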

Compound 4, a percentage reported as inhibition, at one concentration (the size of the read-out at that concentration, not a potency): 80%
The estimate for compound 4 equals the measured number at the digits printed; measured number inside the range.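

In this assay, methoxy in place of methyl gives no change at the digits printed from compound 3 to compound 4 (within the scatter), and this exchange carries over from one core to the other: the same change on two cores in this assay, no change at the digits printed (within the scatter) from compound 1 to compound 2 and no change at the digits printed (within the scatter) from compound 3 to compound 4, 0 percentage points apart, within the scatter of two such steps Chloro in place of fluoro gives no change at the digits printed from compound 2 to compound 4 (within the scatter), and it carries over in the same way: the same change on two cores in this assay, no change at the digits printed (within the scatter) from compound 1 to compound 3 and no change at the digits printed (within the scatter) from compound 2 to compound 4, 0 percentage points apart, within the scatter of two such steps This shows that neither exchange moved the read-out on either core in these four compounds, but it says nothing about potency: a single concentration cannot give one, and compounds that sit level here could still part at lower concentrations.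

The compounds shown leave open whether the read-out would hold with quite different groups in place of the methyl or methoxy, such as an amine, a carboxylic acid or a longer chain, or with bromo in place of the fluoro or chloro. Also open, as far as these compounds go, is how either exchange would behave on a core that gives a different read-out from these four compounds.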